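The source may report more compounds than this note shows. Statements on the series, on what has been measured and on what is new or still open speak of the compounds shown alone.

Compound 1 `CC(C)C(=O)N1CCC(C[C@@H](c2nc3ccc(F)cc3n2C2CC2)N2C(=O)CN(c3ccc(Oc4ccc(F)cc4)cc3)C2=O)CC1`: > 100000 nM
Compound 2 `CC(C)C(=O)N1CCC(C[C@@H](c2nc3ccccc3n2C2CC2)N2C(=O)CN(c3ccc(Oc4ccc(F)cc4)cc3)C2=O)CC1`: > 100000 nM
Compound 3 `COc1ccc(Oc2ccc(N3CC(=O)N([C@@H](CC4CCN(C(=O)C(C)C)CC4)c4nc5ccc(F)cc5n4C)C3=O)cc2)cc1`: > 100000 nM

All three compounds were tested in an ADME assay on Huh-7 cells (Homo sapiens) for cytotoxicity, read by MTT assay (on this read-out higher numbers stand for weaker inhibition and lower numbers for stronger inhibition), and the series sits at the limit of > 100000 nM in this assay, at which 3 of the 3 values shown sit. Compound 3 gives > 100000 nM, which is a limit and not a number. Compound 4 `CC(C)C(=O)N1CCC(C[C@@H](c2nc3ccc(F)cc3n2C)N2C(=O)CN(c3ccc(Oc4ccc(F)cc4)cc3)C2=O)CC1` differs from compound 3 in one place, with fluoro in place of methoxy on an aromatic carbon. For the measured compounds named here, the only measured step, hydrogen in place of fluoro on an aromatic carbon, is a step that the two limits leave unreadable from compound 1 to compound 2, so it offers no size to carry over. The expectation therefore rests on compound 3, whose > 100000 nM is a limit. No change beyond the scatter is expected in this assay, and the estimated step is a number no higher from compound 3 to compound 4 (the limit leaves the size open). Compound 4 is expected at 100000 nM, with an estimated range of 50000 nM to 200000 nM.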

Compound 4, half-maximal inhibitory concentration: > 100000 nM
Compound 4: no number, only a limit; the forecaster's own chance of this, stated with the estimate: 85%; the middle value sits exactly at the limit.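

In this assay, for the compounds shown here, compound 4 gives > 100000 nM, which is a limit and not a number, so no step from compound 1, compound 2 or compound 3 to compound 4 can be read. The compounds shown leave open whether any of these changes shifts the read-out at all, as every value sits at one limit: the limit of > 100000 nM in this assay, at which 4 of the 4 values shown sit.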